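The compounds below may be only part of what the source reports. "The series", "measured", "known", "first", "only" and "open" are said of these compounds alone.

Compound 1 `CC(C)(C)Cc1c(-c2cccc(F)c2F)sc(N)c1C(=O)c1ccc(Cl)cc1`, compound 2 `CC(C)(C)Cc1c(-c2cc(F)ccc2F)sc(N)c1C(=O)c1ccc(Cl)cc1` and compound 3 `CC(C)(C)Cc1c(/C=C/c2ccc(Cl)cc2)sc(N)c1C(=O)c1ccc(Cl)cc1` share one core and differ only in the group carried on a single aromatic carbon. In an assay on CHO cells for displacement of a labelled ligand from adenosine receptor A1 (Homo sapiens), read by scintillation counting, tested at 10 uM (a higher number here means more inhibition at the concentration tested (going by the name of the read-out), a lower number less inhibition), compound 1 gives 1%, compound 2 gives 3% and compound 3 gives 1%. The steps among the three are small: a number 2 percentage points higher from compound 1 to compound 2 (within the scatter), no change at the digits printed from compound 1 to compound 3 (within the scatter) and a number 2 percentage points lower from compound 2 to compound 3 (within the scatter). Compound 3 therefore stands level with compound 1 at the digits shown, the two together the lowest of three numbers, with compound 2 nearest; no pair of the three is separated beyond the scatter.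

Compound 4 `CC(C)(C)Cc1c(Br)sc(N)c1C(=O)c1ccc(Cl)cc1` has not yet been measured. The change from compound 3 is bromo in place of 2-(4-chlorophenyl)ethenyl on an aromatic carbon. For the measured compounds named here, none of the measured steps exchanges a group for a single halogen atom, so there is no direct match. Going by the values given here, the steps that bear on it are the three above, all within the scatter, and they show that swapping one of the three groups tried at this carbon for another left the read-out flat and close to zero. The expectation for compound 4 is accordingly no step beyond the scatter, an estimated a number 2 percentage points higher from compound 3 to compound 4 (within the scatter). Compound 4 is expected to give about 3%, within a range of 0% to 15%.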

Compound 4, a percentage reported as inhibition, at one concentration (the size of the read-out at that concentration, not a potency): 1%
For compound 4 the middle estimate is 2 percentage points above the measured one; low and high end bracket the measured number.
By their numbers in this assay, from the lowest: compounds 1, 3, 4 and 2 (each within the scatter of the next).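

In this assay, replacing a group of 9 heavy atoms with one six-membered aromatic ring by bromo, a single atom with no ring, gives no change at the digits printed from compound 3 to compound 4 (within the scatter). The same holds when bromo takes the place of either difluorophenyl group (a number 2 percentage points lower from compound 2 to compound 4 (within the scatter); no change at the digits printed from compound 1 to compound 4 (within the scatter)). The earlier compounds shown here covered only exchanges among groups that carry an aromatic ring, whereas these steps show that at this carbon next to the ring sulfur, a ring-bearing group and a lone bromo cannot be told apart in this read-out at the one concentration tested.

On these data alone, with all four compounds close to zero and no step beyond the scatter, it remains open whether an amine, a carboxylic acid or a longer alkyl chain at this carbon would move the read-out, or whether changing the neopentyl, amino or (4-chlorophenyl)carbonyl group would. Nothing at hand offers an explanation for the flat read-out at this position.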